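This account rests on a few compounds, and the source may have more. Where it says the series, first, only, none or still open, it means among the compounds named here.

Measured so far in a physicochemical assay for lipophilicity, using the shake flask method, in phosphate buffer, measured as octanol-water partition, at pH 7.4; a higher number here means a more lipophilic compound, a lower number a more polar compound:
compound 1 `COc1cc(-c2cc(C(=O)O)c3ccccc3n2)ccc1OCC(=O)Nc1cccc(C)c1` gives 1.5
compound 2 `COc1cc(-c2cc(C(=O)O)c3ccccc3n2)ccc1OCC(=O)Nc1ccc(Cl)cc1` gives 1.5

Going by the values given here, compound 2 stands level with compound 1 in this assay, the only step on record, no change at the digits printed from compound 1 to compound 2 (within the scatter), lying within the scatter. Compound 3 `COc1cc(-c2cc(C(=O)O)c3ccccc3n2)ccc1OCC(=O)NCc1cccnc1` differs from compound 2 by (pyridin-3-yl)methyl in place of 4-chlorophenyl on an amide-type nitrogen. Among the compounds with values here, no measured step bears directly on this change; the one recorded step swapped two carbon-only aryl groups and moved nothing, whereas here an aromatic ring with one hetero atom and one hydrogen-bond acceptor enters through a methylene link. A step downward beyond the scatter is therefore expected, a number 1.70 log units lower from compound 2 to compound 3 (beyond the scatter). Compound 3 is estimated at -0.2, within -1 to 0.6.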

Compound 3, distribution coefficient: -0.8
Compound 3: the middle estimate sits 0.60 log units above what was measured, within the range that was stated.
By their numbers in this assay, from the lowest: compound 3; then compounds 1 and 2 (each within the scatter of the next).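

On the amide-type nitrogen, this assay responds to this change: (pyridin-3-yl)methyl in place of 4-chlorophenyl gives a number 2.30 log units lower from compound 2 to compound 3 (beyond the scatter) and, in place of 3-methylphenyl, gives a number 2.30 log units lower from compound 1 to compound 3 (beyond the scatter) in a matching drop. The position therefore does not stay flat across every replacement, although the exchange between two carbon-only aryl groups left the number level. No measurement here bears on the reason for the drop.

The compounds shown leave open whether the methylene link or the ring nitrogen carries the step, which a benzyl group or a pyridin-3-yl group set directly on this nitrogen would separate. On these data alone, how an amine or a longer chain would read here also stays open.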